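Anilide to pyridyl amide swap on the shared core

A few compounds are considered here, and "the series" means these few. Any claim that something is new, unique, unknown or untested is made for them only; others in the source may bear on it.

Compound 1 `CSc1ccc2nc(C)cc(OCC(=O)Nc3cc(C)cc(C)c3)c2c1` reaches only a limit in a toxicity assay on HepG2 cells (Homo sapiens) for inhibition, read by CellTiter-Glo, with a stated time of 48 h (on this read-out lower numbers stand for stronger inhibition and higher numbers for weaker inhibition), > 100000 nM. Compound 2 `COc1ccc2nc(C)cc(OCCNc3cc(C)cc(C)c3)c2c1` gives 31600 nM in this assay. Compound 3 `COc1ccc2nc(C)cc(OCC(=O)Nc3c(C)cccc3C)c2c1` likewise reaches only a limit in this assay, > 100000 nM. Among the measured compounds shown here, compound 3 thus stands at the limit shared by two of the three values shown (the limit of > 100000 nM in this assay, at which 2 of the 3 values shown sit); no step between measured compounds is defined, and compound 2 alone yields a number. Compound 4 `COc1ccc2nc(C)cc(OCC(=O)Nc3ccccn3)c2c1` carries pyridin-2-yl in place of 2,6-dimethylphenyl on an amide-type nitrogen. For the measured compounds named here, with compound 3 itself only a limit and no measured step to draw on, no movement beyond the scatter is expected in this assay. The step of a number no higher from compound 3 to compound 4 (the limit leaves the size open) that the estimate means is expected to stay within the scatter. Compound 4 is estimated at 100000 nM, between 40000 nM and 250000 nM.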

Compound 4, half-maximal inhibitory concentration: > 100000 nM
Compound 4: a limit, no number (the forecaster's own chance of this, stated with the estimate: 70%); the middle value sits exactly at the limit.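

Compound 3 and compound 4 each give only a limit in this assay, and no step can be read between them. The compounds shown leave open whether pyridin-2-yl in place of 2,6-dimethylphenyl changes inhibition at all, with most values at one limit: the limit of > 100000 nM in this assay, at which 3 of the 4 values shown sit.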